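This account rests on a few compounds, and the source may have more. Where it says the series, first, only, none or still open, it means among the compounds named here.

Three compounds have been measured in a functional assay on the whole organism (strain L.) for inhibition, with Echinochloa crus-galli as the target, with a stated time of 72 h, tested at 100 mg/L; a lower number here means less inhibition of growth, a higher number more inhibition of growth at the concentration tested:

compound 1, `COc1cc(Cl)nc2n/c(=N/C(=O)c3c(-c4ccc(Cl)cc4Cl)noc3C)sn12`, giving 40.8%;
compound 2, `COc1cc(C)nc(NC(=S)NC(=O)c2c(-c3ccc(Cl)cc3Cl)noc2C)n1`, giving 61.8%;
compound 3, `COc1cc(SC)nc2n/c(=N/C(=O)c3c(-c4ccc(Cl)cc4Cl)noc3C)sn12`, giving 55.6%.

Compound 2 gives the largest of the three numbers, but its separation from compound 3 lies within the scatter, so the two cannot be told apart on these data; only compound 1 stands clearly lower than compound 2. Among the compounds with values here, the single step measured between compounds that differ in one place is a number 14.8 percentage points higher from compound 1 to compound 3 (beyond the scatter), and it concerns the core of compound 1, not the core of compound 2.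

Compound 4, `COc1cc(OC)nc(NC(=S)NC(=O)c2c(-c3ccc(Cl)cc3Cl)noc2C)n1`, has not yet been measured. It differs from compound 2 in one place: methoxy in place of methyl on an aromatic carbon. Within the data shown here, no measured step covers this change on either core, and the one step that was measured, on the core of compound 1, was modest. The account therefore expects no step beyond the scatter in this assay on going from compound 2 to compound 4, and a number close to that of compound 2. The step that this estimate means is a number 1.8 percentage points lower from compound 2 to compound 4 (within the scatter). For compound 4 the expected value is 60%, with a range from 42% to 78%.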

Compound 4, percent growth inhibition at one concentration: 60.9%
For compound 4 the middle estimate is 0.9 percentage points below the measured one, and the stated range covers the measured number.
By their numbers in this assay, from the lowest: compound 1; then compounds 3, 4 and 2 (each within the scatter of the next).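

In this assay, the change from 4-methoxy-6-methylpyrimidin-2-yl to 4,6-dimethoxypyrimidin-2-yl gives a number 0.9 percentage points lower from compound 2 to compound 4 (within the scatter). Within the data shown here, on the core of compound 2, then, this change next to the ring nitrogen produces no step that can be told from the scatter, and this is the only step measured on that core. The other measured step, a number 14.8 percentage points higher from compound 1 to compound 3 (beyond the scatter), lies beyond the scatter, but it is a different change on the core of compound 1, so it says nothing directly about this position on the core of compound 2, and no evidence is available on why the number stays where it does.

The compounds shown leave open whether methoxy in place of methyl would give a similar result on the core of compound 1. They also leave open whether an amine, an ethoxy group or a longer chain at this same place would stay within the scatter of compound 2 and compound 4, or would move the number beyond it.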